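Second Chloro on the Core: Compound 4 Expected

A few compounds are considered here, and "the series" means these few. Any claim that something is new, unique, unknown or untested is made for them only; others in the source may bear on it.

Measured compounds:
compound 1 `ClCc1cccc(Cn2cnc3ncnc(Cl)c32)c1` — > 100000 nM
compound 2 `ClCc1ccccc1Cn1cnc2ncnc(Cl)c21` — 26900 nM
compound 3 `ClCc1cccc(Cn2cnc3nc(Cl)nc(Cl)c32)c1` — 6300 nM

In a functional assay on OVCAR-5 cells (Homo sapiens) for cytotoxicity, read by sulforhodamine B assay, with a stated time of 48 h (a higher number here means that more compound is tolerated, a lower number that less compound is tolerated), compound 1 gives > 100000 nM, which is a limit of the assay and not a number (the limit of > 100000 nM in this assay, at which 1 of the 3 values shown sits). Compound 2 gives 26900 nM in this assay, and compound 3 gives 6300 nM. The change chloro in place of hydrogen on an aromatic carbon produced an at least 15-fold lower number from compound 1 to compound 3 (1.20 log units; beyond the scatter). How the cores of compound 1 and compound 2 differ is not broken down here. Compound 4 `ClCc1ccccc1Cn1cnc2nc(Cl)nc(Cl)c21` carries the same change, (chloro in place of hydrogen on an aromatic carbon), made on the core of compound 2. From compound 2 to compound 4 a step of a 9.0-fold lower number from compound 2 to compound 4 (0.95 log units; beyond the scatter) is expected, resting on the step of an at least 15-fold lower number from compound 1 to compound 3 (1.20 log units; beyond the scatter), though that step is only a lower bound. Compound 4 is estimated at 3000 nM, between 800 nM and 10000 nM.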

Compound 4, concentration lethal to 50% of the cells: 28800 nM
Compound 4: middle estimate off by 9.6-fold (0.98 log units), on the low side, and the stated range ends below it.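

In this assay, the chloro in place of hydrogen on an aromatic carbon gives a 1.1-fold higher number from compound 2 to compound 4 (0.03 log units; within the scatter), so on this core the two values cannot be told apart. The same change therefore does not carry over from one core to the other with the same size: the same change on two cores in this assay, an at least 15-fold lower number (1.20 log units; beyond the scatter) from compound 1 to compound 3 and a 1.1-fold higher number (0.03 log units; within the scatter) from compound 2 to compound 4, at least 16-fold (1.23 log units) apart, beyond the scatter of two such steps. Compound 1 gives a limit of the assay and not a number, so the full size of the first step is unknown, and two cores show neither why the steps differ nor what other cores would do: the limit of > 100000 nM in this assay, at which 1 of the 4 values shown sits.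

The compounds shown leave open whether a different group on that aromatic carbon, such as an amine, would act alike on both cores.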